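Series notes: trifluoromethyl in place of chloro

A few compounds are considered here, and "the series" means these few. Any claim that something is new, unique, unknown or untested is made for them only; others in the source may bear on it.

Measured so far, in a functional assay on RPMI-8226 cells (Homo sapiens) for inhibition, read by sulforhodamine B assay, with a stated time of 48 h; a higher number here means a weaker inhibitor, a lower number a stronger inhibitor:
compound 1 `O=C(Nc1cccc(-n2cc(-c3ccncc3)c(-c3ccc(Cl)c(O)c3)n2)c1)Nc1ccc(Cl)c(Cl)c1` gives 1030 nM
compound 2 `COc1cc(-c2nn(-c3cccc(NC(=O)c4cccc(C(F)(F)F)c4)c3)cc2-c2ccncc2)ccc1Cl` gives 1570 nM
compound 3 `COc1cc(-c2nn(-c3cccc(NC(=O)c4ccccc4)c3)cc2-c2ccncc2)ccc1Cl` gives 850 nM

Compound 1 sits in the middle of the three numbers, and all three lie within the usual scatter of one another, so no ranking among them is supported.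

The next compound, compound 4 `O=C(Nc1cccc(-n2cc(-c3ccncc3)c(-c3ccc(Cl)c(O)c3)n2)c1)Nc1ccc(Cl)c(C(F)(F)F)c1`, differs from compound 1 in one place: trifluoromethyl in place of chloro on an aromatic carbon. Among the compounds with values here, the only measured step of a related kind is a 1.8-fold lower number from compound 2 to compound 3 (0.27 log units; within the scatter), where hydrogen replaces trifluoromethyl on a different aromatic ring of the same core; that step stayed within the scatter. Within the data shown here, no step exchanging chloro for trifluoromethyl has been measured, and the one step that does involve trifluoromethyl gives no sign of a shift beyond the scatter. The expectation for compound 4 in this assay is therefore a step of a 1.1-fold higher number from compound 1 to compound 4 (0.03 log units; within the scatter), that is, no change beyond the scatter. Compound 4 is estimated at 1100 nM, with a range from 500 nM to 2500 nM.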

Compound 4, half-maximal inhibitory concentration: 580 nM
For compound 4 the middle estimate is 1.9-fold (0.28 log units) above the measured one, within the range that was stated.
By their numbers in this assay, from the lowest: compounds 4, 3, 1 and 2 (each within the scatter of the next, the first and the last beyond it).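

Within the data shown here, the first chloro-to-trifluoromethyl exchange, on an aromatic carbon ortho to a chloro group and meta to a large group, gives in this assay a 1.8-fold lower number from compound 1 to compound 4 (0.25 log units; within the scatter). This position therefore takes trifluoromethyl, with 4 heavy atoms in place of 1, without a change beyond the scatter, and the step between compound 2 and compound 3, on a different aromatic ring, also stays within it. No measurement shown bears on the reason for this result.

Among the compounds shown, this position carries only chloro or trifluoromethyl, so a sharper reading of its tolerance is still lacking. From the compounds shown here alone, whether an amine, a carboxylic acid or a longer alkyl chain here would move the number beyond the scatter remains open.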